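The compounds below may be only part of what the source reports. "The series", "measured", "known", "first", "only" and "open" are said of these compounds alone.

Measured so far:
Compound 1, `Cc1ccc(Nc2cc(NC(=O)Nc3c(Cl)cccc3Cl)ncn2)cc1C`: 47.5% in a functional assay on NCI-H520 cells (Homo sapiens) for inhibition, read by MTT assay, with a stated time of 48 h, tested at 10 uM; on this read-out lower numbers stand for less inhibition and higher numbers for more inhibition at the one concentration tested (going by the name of the read-out)
Compound 2, `Cc1cc(F)cc(Nc2cc(NC(=O)Nc3c(Cl)cccc3Cl)ncn2)c1`: 60.5% in this assay

Both compounds share one core and differ only in the aryl group on a nitrogen on an aromatic ring. Compound 2 gives the higher of the two numbers in this assay; the step of a number 13 percentage points higher from compound 1 to compound 2 (beyond the scatter) lies beyond the scatter. Compound 3, `COc1ccc(Br)cc1Nc1cc(NC(=O)Nc2c(Cl)cccc2Cl)ncn1`, keeps the core and changes the same group: 5-bromo-2-methoxyphenyl in place of 3-fluoro-5-methylphenyl on a nitrogen on an aromatic ring. For the measured compounds named here, the only measured step that bears on this change is the one at the same position, a number 13 percentage points higher from compound 1 to compound 2 (beyond the scatter), a modest shift from swapping one aryl group for another on that nitrogen. The entering group, 5-bromo-2-methoxyphenyl, was not measured in any compound here, so the direction of the step is not fixed by the data; a change of similar modest size, in either direction, seems about as likely as none beyond the scatter. For compound 3 the estimate in this assay is 55%, with a range from 38% to 72%. The expected step is a number 5.5 percentage points lower from compound 2 to compound 3 (within the scatter).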

Compound 3, a percentage reported as inhibition, at one concentration (the size of the read-out at that concentration, not a potency): 45%
Compound 3: middle estimate off by 10 percentage points, on the high side; the range from low to high includes it.
By their numbers in this assay, from the lowest: compounds 3 and 1 (each within the scatter of the next); then compound 2.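

In this assay, putting 5-bromo-2-methoxyphenyl in place of 3-fluoro-5-methylphenyl on the nitrogen gives a number 15.5 percentage points lower from compound 2 to compound 3 (beyond the scatter). For the compounds shown here, the earlier compounds showed only one upward step at this position, and this result shows that a swap of one aryl group for another can also take the number down by a similar modest amount. Set against 3,4-dimethylphenyl, the same entering group gives a number 2.5 percentage points lower from compound 1 to compound 3 (within the scatter), so these two differently substituted rings cannot be told apart here, while 3-fluoro-5-methylphenyl stands clear of both. No independent measurement is available to explain these differences.

On these data alone, the entering group brings in bromine and methoxy together, so it remains open whether either one alone, on an otherwise plain phenyl ring, would account for the step from the fluoro-methyl compound. Also open, as far as these compounds go, is how the shared core behaves when this nitrogen carries something other than a substituted phenyl ring, such as a pyridine ring, a phenyl ring bearing a carboxylic acid, or a simple alkyl chain.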